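The source may hold more compounds than are shown below. What is called first, only, known or untested is meant among the compounds shown, and "the series" means these compounds.

Measured in a functional assay on HCT-116 cells (Homo sapiens) for inhibition, read by CCK-8 assay, with a stated time of 48 h; on this read-out higher numbers stand for weaker inhibition and lower numbers for stronger inhibition:
- compound 1 `COc1cc(-c2ccnc3cc(-c4ccc(F)cc4)nn23)cc(OC)c1OC`: 5030 nM
- compound 2 `COc1cc(-c2cc3nccc(-c4c[nH]c5ccccc45)n3n2)cc(OC)c1OC`: > 10000 nM (a limit of the assay)
- compound 3 `Cn1ccc2cc(-c3cc4nccc(-c5ccc(F)cc5)n4n3)ccc21`: 2160 nM

Of the two true numbers, the higher belongs to compound 1, at 5030 nM. Compound 3 lies lower, at 2160 nM, a gap beyond the usual scatter. The entry for compound 2 is a limit and not a number, so it cannot be ranked against the others.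

Compound 4 `COc1cc(-c2ccnc3cc(-c4ccc(C)c(C)c4)nn23)cc(OC)c1OC` keeps the core of compound 1 and carries 3,4-dimethylphenyl in place of 4-fluorophenyl on an aromatic carbon. Among the measured compounds shown here, no pair of measured compounds isolates this exchange, so the series gives no direct guide to its size. In this assay, no change beyond the scatter is expected, with the starting point being compound 1 at 5030 nM. The estimated result is a 1.1-fold higher number from compound 1 to compound 4 (0.04 log units; within the scatter). Compound 4 is expected at about 5500 nM, with an estimated range of 2200 nM to 12000 nM.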

Compound 4, half-maximal inhibitory concentration: 261 nM
For compound 4 the middle estimate is 21-fold (1.32 log units) above the measured one; measured number outside the range, below it.
By their numbers in this assay, from the lowest: compound 4; then compound 3; then compound 1. At a limit, above all of these: compound 2.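

In this assay, among the compounds shown here, the exchange of 4-fluorophenyl for 3,4-dimethylphenyl gives a 19-fold lower number from compound 1 to compound 4 (1.28 log units; beyond the scatter), the first direct reading of this position on the aromatic carbon of the five-membered ring. The position is therefore sensitive to the group it carries, even though the two groups are close in what can be counted: each is one six-membered aromatic ring of carbon only, with no hydrogen-bond donors or acceptors and no net charge, and the entering group has only one more heavy atom. Nothing measured in the series bears on why the step is this large.

Open, from the compounds shown here alone, is whether a single methyl group would account for the step, and whether an amine or a carboxylic acid on this phenyl ring would keep it. Also open, going by these compounds, is whether the same exchange on compound 3 would give a step of like size.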